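Swapping chloro for trifluoromethyl in compound 2

The source may hold more compounds than are shown below. What is called first, only, known or untested is meant among the compounds shown, and "the series" means these compounds.

Three compounds have been measured in a functional assay on the whole organism (strain Swiss) with Mus musculus as the target, in the maximal electroshock model, with a stated time of 0.25 h; on this read-out lower numbers stand for an effect already at smaller amounts and higher numbers for an effect only at larger amounts of compound:
compound 1, `CCC(C(=O)N1CCN(c2cccc(Cl)c2)CC1)N1C(=O)CC(C)C1=O`, 117 mg/kg
compound 2, `CC1CC(=O)N(C(C)C(=O)N2CCN(c3cccc(Cl)c3)CC2)C1=O`, 89.7 mg/kg
compound 3, `CC(C(=O)N1CCN(c2cccc(Cl)c2)CC1)N1C(=O)CC(C)(C)C1=O`, 120 mg/kg

Compound 2 stands at 89.7 mg/kg in this assay, and the other two lie close to it: the step of a 1.3-fold lower number from compound 1 to compound 2 (0.12 log units; within the scatter) and the step of a 1.3-fold higher number from compound 2 to compound 3 (0.13 log units; within the scatter) are both within the scatter, so the three numbers cannot be told apart. Both of those steps alter the saturated part of the shared core, one a methyl on the chain carbon and one a methyl on the ring carbon, and neither touches the aromatic ring.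

Compound 4, `CC1CC(=O)N(C(C)C(=O)N2CCN(c3cccc(C(F)(F)F)c3)CC2)C1=O`, differs from compound 2 in exactly that untouched place: trifluoromethyl in place of chloro on an aromatic carbon. Among the measured compounds shown here, no measured step bears on a change at the aromatic ring, so nothing in the data points in either direction. Since the two changes that were measured moved the number by a 1.3-fold lower number from compound 1 to compound 2 (0.12 log units; within the scatter) and a 1.3-fold higher number from compound 2 to compound 3 (0.13 log units; within the scatter) only, the step from compound 2 to compound 4 is expected to be a 1.1-fold higher number from compound 2 to compound 4 (0.02 log units; within the scatter), that is, nothing beyond the scatter. For compound 4 the estimate in this assay is 95 mg/kg, with a range from 45 mg/kg to 200 mg/kg.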

Compound 4, dose for half-maximal effect: 81.7 mg/kg
Beside the measured number, compound 4's estimate is 1.2-fold (0.07 log units) above it; the range from low to high includes it.
By their numbers in this assay, from the lowest: compounds 4, 2, 1 and 3 (each within the scatter of the next).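

In this assay, among the compounds shown here, the only step at the aromatic ring, a 1.1-fold lower number from compound 2 to compound 4 (0.04 log units; within the scatter), stays within the scatter, so trifluoromethyl and chloro cannot be told apart on this aromatic carbon, meta to a large group. For the compounds shown here, the earlier steps touched only the saturated part of the shared core, so this is the first reading of the aromatic position: here, a group of 4 heavy atoms taking the place of a single chlorine leaves the number indistinguishable from that of compound 2, just as the two methyl changes did on the saturated part. No evidence is available on what lies behind this result.

Going by these compounds, whether a different group on this aromatic carbon, such as a nitrile, a methoxy group or plain hydrogen in place of chloro, would move the number beyond the scatter remains open. On these data alone, it also remains open whether trifluoromethyl in place of chloro would give the same result in compound 1 or compound 3, which carry different methyl patterns on the saturated part.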